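Swapping a benzyl for a methylsulfanylmethyl on the core

The compounds below may be only part of what the source reports. "The series", "measured", "known", "first", "only" and "open" are said of these compounds alone.

Compound 1 `CCCCCCc1ccc2nc(N)sc2c1` gives 7 mg/kg in a functional assay on the whole organism with Rattus norvegicus as the target; a lower number here means that less compound is needed, a higher number that more compound is needed for the effect.
Compound 2 `Nc1nc2ccc(C(F)(F)C(F)(F)F)cc2s1` gives 2.5 mg/kg.
Compound 3 `N=c1sc2cc(OC(F)(F)F)ccc2n1Cc1ccccc1` gives > 10 mg/kg.

Compounds 1 and 2 each carry a free amine on the shared core and both give a number in this assay. Compound 3 is different in kind: its core bears a benzyl group on the ring nitrogen, and for compound 3 the result is a limit of the assay, not a number (the limit of > 10 mg/kg in this assay, at which 1 of the 3 values shown sits). Nothing more can be said of where compound 3 stands than that its dose, if any, lies past that limit.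

Compound 4 `CSCn1c(=N)sc2cc(OC(F)(F)F)ccc21` keeps the same core and the same trifluoromethoxy group, and changes only the group on the ring nitrogen: methylsulfanyl in place of phenyl on a saturated chain carbon bound to an aromatic nitrogen. Because compound 3 is known only as a limit, the size of the step cannot be anchored to a measured number; what is expected is a value near that limit, with a step that the limit leaves unreadable from compound 3 to compound 4 that is only an estimate. Compound 4 is expected to give about 12 mg/kg in this assay, somewhere between 4 mg/kg and 40 mg/kg, and it may well again return only a limit.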

Compound 4, dose for half-maximal effect: 3 mg/kg
Compound 4: the middle estimate sits 4.0-fold (0.60 log units) above what was measured, outside the stated range (below it).
By their numbers in this assay, from the lowest: compounds 2 and 4 (each within the scatter of the next); then compound 1. At a limit, above all of these: compound 3.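

Putting methylsulfanyl in place of phenyl on a saturated chain carbon bound to an aromatic nitrogen gives, in this assay, an at least 3.3-fold lower number from compound 3 to compound 4 (0.52 log units; beyond the scatter). This shows that the group on the ring nitrogen can decide whether a compound of this kind gives a number at all: with (methylsulfanyl)methyl there, compound 4 gives 3 mg/kg, and the phenyl ring of the benzyl group is not needed for that result. The value of compound 3 is a limit of the assay and not a number, so the step has a known minimum but no known full size: the limit of > 10 mg/kg in this assay, at which 1 of the 4 values shown sits.

What the compounds shown leave open is which feature of the change matters, whether the sulfur of the methylsulfanyl group, the smaller size of the group or the absence of a ring. A plain ethyl chain, a methoxymethyl group with oxygen in place of the sulfur, or a longer chain on the same ring nitrogen would help to tell these apart.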